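The source may hold more compounds than are shown below. What is called first, only, known or untested is meant among the compounds shown, and "the series" means these compounds.

Compound 1 `Nc1nc(-c2ccccc2)cn1/N=C/c1cc2ccccc2nc1Cl` gives 16400 nM in a functional assay on DLD-1 cells (Homo sapiens) for cytotoxicity, read by MTT assay, with a stated time of 48 h; on this read-out lower numbers stand for stronger inhibition and higher numbers for weaker inhibition.
Compound 2 `COc1ccc(-c2cn(/N=C/c3cc4ccccc4nc3Cl)c(N)n2)cc1` reaches only the limit of this assay, > 50000 nM.
Compound 3 `Nc1nc(-c2ccc(Br)cc2)cn1/N=C/c1cc2ccccc2nc1Cl` gives 23900 nM in this assay.

Compound 3 stands at the highest of the two numbers actually read in this assay, its nearest neighbour being compound 1, from which it is separated by a 1.5-fold higher number from compound 1 to compound 3 (0.16 log units; within the scatter), a gap within the scatter. The pair of compound 2 and compound 3 shows an at least 2.0-fold lower number from compound 2 to compound 3 (0.32 log units; beyond the scatter), and that gap is beyond the scatter. Compound 4 `Nc1nc(-c2cccs2)cn1/N=C/c1cc2ccccc2nc1Cl` differs from compound 3 by thiophen-2-yl in place of 4-bromophenyl on an aromatic carbon. Among the compounds with values here, none of the measured steps changes the ring itself: the steps from compound 1 to compound 3 and from compound 2 to compound 3 alter only a substituent on the 4-position of a six-membered ring, so they speak only indirectly to the exchange of that ring for thiophen-2-yl. With the shared core held constant and the aromatic group merely reshaped, no step beyond the scatter is expected in this assay for compound 4. Compound 4 is therefore estimated at 18000 nM, within 7000 nM to 50000 nM, which would amount to a 1.3-fold lower number from compound 3 to compound 4 (0.12 log units; within the scatter).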

Compound 4, half-maximal inhibitory concentration: 10300 nM
The estimate for compound 4 lay 1.7-fold (0.24 log units) above the measured number, and the stated range covers the measured number.
By their numbers in this assay, from the lowest: compounds 4, 1 and 3 (each within the scatter of the next, the first and the last beyond it). At a limit, above all of these: compound 2.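

Within the data shown here, exchanging the ring itself at this position, rather than a substituent on it, can be read for the first time in this assay, and replacing 4-bromophenyl with thiophen-2-yl gives a 2.3-fold lower number from compound 3 to compound 4 (0.37 log units; beyond the scatter) on this carbon of the five-membered aromatic ring with 2 nitrogen. Replacing the unsubstituted phenyl gives only a 1.6-fold lower number from compound 1 to compound 4 (0.20 log units; within the scatter) as the step, so thiophen-2-yl and phenyl cannot be told apart here, and thiophen-2-yl stands clear only of the substituted rings. The step from 4-methoxyphenyl, an at least 4.8-fold lower number from compound 2 to compound 4 (0.68 log units; beyond the scatter) as printed, rests on a limit and not on a number for compound 2: the limit of > 50000 nM in this assay, at which 1 of the 4 values shown sits.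

The compounds shown leave open whether thiophen-3-yl, furan-2-yl or a thiophen-2-yl ring carrying bromo or methoxy would behave alike at this carbon. They also leave open what cyclohexyl or a longer alkyl chain in place of the aromatic ring would give in this assay at this position.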